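A methoxyphenyl swap on compound 1

This account rests on a few compounds, and the source may have more. Where it says the series, first, only, none or still open, it means among the compounds named here.

In a functional assay on the whole organism (strain Kunming) with Mus musculus as the target, with a stated time of 0.5 h (a higher number here means that more compound is needed for the effect, a lower number that less compound is needed), compound 1 (`COc1cc(OC)c(OC)cc1/C=C/COC(=O)/C=C/c1ccccc1C(F)(F)F`) stands at > 473 umol/kg as a limit of the assay and not a number. Compound 2 (`COc1cc(OC)c(OC)cc1/C=C/COC(=O)/C=C/c1cc(OC)c(OC)c(OC)c1`) gives 459 umol/kg and compound 3 (`COc1cc(OC)c(OC)cc1/C=C/COC(=O)/C=C/c1ccc(OC)c(OC)c1OC`) gives 456 umol/kg as measured numbers that agree within the scatter. Compound 4 (`COc1cccc(/C=C/C(=O)OC/C=C/c2cc(OC)c(OC)cc2OC)c1`) has 3-methoxyphenyl in place of 2-(trifluoromethyl)phenyl on a double-bonded chain carbon bound to a double-bonded chain carbon. For the measured compounds named here, no measured step guides this change, so in this assay nothing beyond the scatter is expected and an at least 1.1-fold lower number from compound 1 to compound 4 (0.05 log units; that floor lies within the scatter) is expected to stay small in size. For compound 4 the estimate is 420 umol/kg as the expected value, with an expected range from 230 umol/kg to 560 umol/kg around it.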

Compound 4, dose for half-maximal effect: 643 umol/kg
Compound 4: middle estimate off by 1.5-fold (0.18 log units), on the low side, outside the stated range (above it).
By their numbers in this assay, from the lowest: compounds 3, 2 and 4 (each within the scatter of the next).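

No new step can be read between compound 1 and compound 4, since the value of compound 1 is a limit of the assay and not a number: the limit of > 473 umol/kg in this assay, at which 1 of the 4 values shown sits.

The compounds shown leave open how far 3-methoxyphenyl in place of 2-(trifluoromethyl)phenyl shifts the dose needed in this assay.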